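A few compounds are considered here, and "the series" means these few. Any claim that something is new, unique, unknown or untested is made for them only; others in the source may bear on it.

Measured so far in a functional assay on MDA-MB-231 cells (Homo sapiens) for antiproliferative activity, read by MTT assay, with a stated time of 72 h; on this read-out higher numbers stand for weaker inhibition and lower numbers for stronger inhibition:
- Compound 1 `CC1=CC[C@H]2[C@H](CC[C@]2(C)O)C(C)(C)[C@@H]1CC[C@H]1[C@]2(C)CC[C@H](OC(=O)c3ccccc3)C(C)(C)O[C@H]2CC[C@@]1(C)O`: 16100 nM
- Compound 2 `CC1=CC[C@H]2[C@H](CC[C@]2(C)O)C(C)(C)[C@@H]1CC[C@H]1[C@]2(C)CC[C@H](OC(=O)c3ccccc3Cl)C(C)(C)O[C@H]2CC[C@@]1(C)O`: 24300 nM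

For the measured compounds named here, compound 2, at 24300 nM, cannot be told apart from compound 1, as only two numbers exist and they lie within the scatter of each other. Compound 3 `CC1=CC[C@H]2[C@H](CC[C@]2(C)O)C(C)(C)[C@@H]1CC[C@H]1[C@]2(C)CC[C@H](OC(=O)c3ccc(C(F)(F)F)cc3F)C(C)(C)O[C@H]2CC[C@@]1(C)O` brings one structural change: 2-fluoro-4-(trifluoromethyl)phenyl in place of 2-chlorophenyl on a carbonyl carbon. Going by the values given here, the only measured step that bears on this, a 1.5-fold higher number from compound 1 to compound 2 (0.18 log units; within the scatter), also alters the aromatic ring and stays within the scatter, so no step beyond the scatter is expected in this assay. The estimated value for compound 3 is 18000 nM, expected to fall between 7000 nM and 45000 nM.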

Compound 3, half-maximal inhibitory concentration: 36300 nM
Estimate against measurement, compound 3: 2.0-fold (0.30 log units) below, and the stated range covers the measured number.
By their numbers in this assay, from the lowest: compounds 1, 2 and 3 (each within the scatter of the next, the first and the last beyond it).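

In this assay, putting 2-fluoro-4-(trifluoromethyl)phenyl in place of 2-chlorophenyl on the carbonyl carbon gives a 1.5-fold higher number from compound 2 to compound 3 (0.17 log units; within the scatter) and so leaves those two compounds indistinguishable. Set against plain phenyl, the same group gives a 2.3-fold higher number from compound 1 to compound 3 (0.35 log units; beyond the scatter) and thus the first step at this position beyond the scatter, a modest one toward weaker inhibition. No measurement shown here explains that step. Still open, going by these compounds, is whether an amine or a carboxylic acid on the aromatic ring, or a longer chain in its place, would give a lower number than compound 1 does.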